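The compounds below may be only part of what the source reports. "The series", "measured", "known", "first", "only" and "open" are said of these compounds alone.

Compound 1 `COc1ccc(Cl)c(-c2nnc3n2NC(c2ccc[nH]2)S3)c1` and compound 3 `COc1ccc(Cl)c(-c2nnc3n2NC(c2cccn2C)S3)c1` share one core and differ in a single place (methyl in place of hydrogen on an aromatic nitrogen). In a functional assay on the whole organism (strain Wistar Albino) for inhibition, with Rattus norvegicus as the target, read by paw edema, with a stated time of 4 h, at a dose of 20 mg/kg (on this read-out higher numbers stand for more inhibition at the one dose given (going by the name of the read-out) and lower numbers for less inhibition), compound 1 gives 20.6%, and compound 3 gives 20.7%, so the step of a number 0.1 percentage points higher from compound 1 to compound 3 (within the scatter) lies within the scatter. Compound 2 `Cc1occc1-c1nnc2n1NC(c1ccc[nH]1)S2` carries another core; the difference between the two cores is not broken down here. In this assay compound 2 gives 22.7%, within the scatter of both other values. Compound 4 `Cc1occc1-c1nnc2n1NC(c1cccn1C)S2` has not been measured and relates to compound 2 as compound 3 relates to compound 1 (methyl in place of hydrogen on an aromatic nitrogen); the place of the change reads the same in both pairs, so it is the same change. The expected step is a number 0.1 percentage points higher from compound 2 to compound 4 (within the scatter), resting on the measured step of a number 0.1 percentage points higher from compound 1 to compound 3 (within the scatter), which stayed within the scatter. Compound 4 is estimated at 22.8%, most likely between 15% and 31%.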

Compound 4, a percentage reported as inhibition, in the whole organism at one dose (the size of the read-out at that dose, not a potency): 22.4%
Estimate against measurement, compound 4: 0.4 percentage points above; the measured number falls inside the stated range.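

Putting methyl in place of hydrogen on the aromatic nitrogen gives a number 0.3 percentage points lower from compound 2 to compound 4 (within the scatter) in this assay. Set beside the earlier step, the change reads alike on the two cores: the same change on two cores in this assay, a number 0.1 percentage points higher (within the scatter) from compound 1 to compound 3 and a number 0.3 percentage points lower (within the scatter) from compound 2 to compound 4, 0.4 percentage points apart, within the scatter of two such steps

So neither pair shows a difference beyond the scatter, but a change that gives no clear step on either core offers little test of transfer, and these two pairs say nothing about other cores or other doses.

The compounds shown leave open what a longer chain such as ethyl on the aromatic nitrogen would give in this assay. They also leave open what a group carrying an amine or a carboxylic acid would give there.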